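A second methyl on the acid chain

The compounds below may be only part of what the source reports. "The series", "measured", "known", "first", "only" and "open" are said of these compounds alone.

In an ADME assay on the whole organism (strain CD-1) for pharmacokinetics, with Mus musculus as the target, at a dose of 3 mg/kg by the intravenous route (on this read-out lower numbers stand for slow clearance and higher numbers for fast clearance), compound 1 `CN(Cc1ccccc1OCCCCCC(=O)O)C(=O)c1ccc(-c2ccco2)cc1` gives 44 mL/min/kg, while compound 2 `CC(CCCCOc1ccccc1CN(C)C(=O)c1ccc(-c2ccco2)cc1)C(=O)O` gives 3 mL/min/kg, the lower of the two numbers. Compound 3 `CN(Cc1ccccc1OCCCCC(C)(C)C(=O)O)C(=O)c1ccc(-c2ccco2)cc1` follows from compound 2 through (methyl in place of hydrogen on a saturated chain carbon bound to a carbonyl carbon and two saturated chain carbons). Among the compounds with values here, one measured step bears on this change: a 15-fold lower number from compound 1 to compound 2 (1.17 log units; beyond the scatter), a large drop on a related replacement of hydrogen by methyl. Within the data shown here, no measured compound shows a second such replacement, so that drop is not expected to repeat in full. A small further fall is expected, a 1.2-fold lower number from compound 2 to compound 3 (0.08 log units; within the scatter), which would stay within the scatter. For compound 3 the estimate is 2.5 mL/min/kg, with an expected range of 0.8 mL/min/kg to 8 mL/min/kg.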

Compound 3, clearance: 1.3 mL/min/kg
Estimate against measurement, compound 3: 1.9-fold (0.28 log units) above; the measured number falls inside the stated range.
By their numbers in this assay, from the lowest: compound 3; then compound 2; then compound 1.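

In this assay, a second methyl on the saturated chain carbon bound to the carbonyl carbon still lowers the number, giving a 2.3-fold lower number from compound 2 to compound 3 (0.36 log units; beyond the scatter), so the first methyl did not exhaust the change at this position, although the second step is far smaller. Overall, the 1-carboxy-1-methylethyl group gives a 34-fold lower number from compound 1 to compound 3 (1.53 log units; beyond the scatter). Nothing available accounts for either fall. The compounds shown leave open whether an ethyl group or a cyclopropyl ring at this carbon would lower the number further. They also leave open how a longer chain or an amide in place of the carboxylic acid would read.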